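Compound 3 and the Swap of Methoxy for Chloro

The compounds below may be only part of what the source reports. "The series", "measured", "known", "first", "only" and "open" are said of these compounds alone.

compound 1 `COc1cccc(C2CC(=O)c3ccccc3N2)c1`: 0.32 ug/mL
compound 2 `COc1cccc([C@@H]2CC(=O)c3ccccc3N2)c1`: 0.15 ug/mL
compound 3 `COc1cccc(C2CC(=O)c3cc(N4CCCC4)ccc3N2)c1`: 0.008 ug/mL

In a functional assay on CAKI-1 cells (Homo sapiens) for cytotoxicity, read by sulforhodamine B assay (a higher number here means that more compound is needed for the effect, a lower number that less compound is needed), compound 3 gives the lowest number of the three, and both gaps to the other compounds lie beyond the scatter. Compound 4 `O=C1CC(c2cccc(Cl)c2)Nc2ccc(N3CCCC3)cc21` replaces 3-methoxyphenyl with 3-chlorophenyl: chloro in place of methoxy on an aromatic carbon. The large step of a 40-fold lower number from compound 1 to compound 3 (1.60 log units; beyond the scatter) came from adding pyrrolidin-1-yl, which compound 4 retains. The modest step of a 2.1-fold lower number from compound 1 to compound 2 (0.33 log units; beyond the scatter) reflects (the fact that one of compounds 1 and 2 is drawn with a defined configuration and the other without, at the place where they differ). Neither step touches the methoxy, so the size of this change remains poorly defined. With compound 3 already at 0.008 ug/mL, a modest rise is expected rather than a further fall. The expected change is a 2.5-fold higher number from compound 3 to compound 4 (0.40 log units; beyond the scatter). Compound 4 is estimated at 0.02 ug/mL, within an expected range of 0.004 ug/mL to 0.1 ug/mL.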

Compound 4, concentration for half-maximal effect: 0.95 ug/mL
Compound 4: the middle estimate sits 48-fold (1.68 log units) below what was measured; the whole stated range lies below it.
By their numbers in this assay, from the lowest: compound 3; then compound 2; then compound 1; then compound 4.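

Chloro in place of methoxy on this aromatic carbon gives a 120-fold higher number from compound 3 to compound 4 (2.07 log units; beyond the scatter) in this assay, the first view of this position, which none of the earlier steps touched. Keeping pyrrolidin-1-yl therefore does not by itself preserve the low number of compound 3, and the group at this position weighs heavily. Nothing available accounts for the size of this step.

With only methoxy and chloro shown here, it remains open whether methoxy helps or chloro harms; a hydroxyl, a methyl or an amine could tell these apart. From the compounds shown here alone, the size of the same swap without pyrrolidin-1-yl also remains open.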